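The compounds below may be only part of what the source reports. "The series", "measured", "known", "first", "only" and "open" are said of these compounds alone.

Measured so far in a functional assay on MCF7 cells (Homo sapiens) for antiproliferative activity, read by MTT assay, with a stated time of 72 h; on this read-out lower numbers stand for stronger inhibition and higher numbers for weaker inhibition
- compound 1 `COc1cc(-n2cnc3ccc(-c4cccc(O)c4)cc32)cc(OC)c1OC` gives 350 nM
- compound 2 `COc1cc(-n2cnc3ccc(-c4cccc(F)c4)cc32)cc(OC)c1OC` gives 2350 nM
- compound 3 `COc1cc(-n2cnc3ccc(-c4cccc(N)c4)cc32)cc(OC)c1OC` gives 180 nM

Compound 3 shares the low end of the series with compound 1, as a 1.9-fold lower number from compound 1 to compound 3 (0.29 log units; within the scatter) shows, and stands well clear of compound 2. Next comes compound 4 `COc1cc(-n2cnc3ccc(-c4ccc(F)cc4)cc32)cc(OC)c1OC`, with 4-fluorophenyl in place of 3-aminophenyl on an aromatic carbon. The closest evidence is the large 13-fold lower number from compound 2 to compound 3 (1.12 log units; beyond the scatter), supported by the modest 6.7-fold higher number from compound 1 to compound 2 (0.83 log units; beyond the scatter). Among the compounds with values here, no measured compound carries the 4-fluorophenyl group, so the effect of moving the fluoro is unknown. A large step to a higher number is therefore expected in this assay. The expected step is an 11-fold higher number from compound 3 to compound 4 (1.05 log units; beyond the scatter). Compound 4 is estimated at 2000 nM, with an expected range of 700 nM to 6000 nM.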

Compound 4, half-maximal inhibitory concentration: 1770 nM
For compound 4 the middle estimate is 1.1-fold (0.05 log units) above the measured one; measured number inside the range.
By their numbers in this assay, from the lowest: compounds 3 and 1 (each within the scatter of the next); then compounds 4 and 2 (each within the scatter of the next).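

In this assay, moving the fluoro leaves the number within the scatter, with a 1.3-fold lower number from compound 2 to compound 4 (0.12 log units; within the scatter), so 3-fluorophenyl and 4-fluorophenyl cannot be told apart here. 4-fluorophenyl also stays clear of the 3-hydroxyphenyl and 3-aminophenyl compounds, with a 5.1-fold higher number from compound 1 to compound 4 (0.70 log units; beyond the scatter) and a 9.8-fold higher number from compound 3 to compound 4 (0.99 log units; beyond the scatter). Nothing on hand accounts for this gap.

As far as these compounds go, whether hydroxy or amino would keep its low number as 4-hydroxyphenyl or 4-aminophenyl remains open. So does whether a carboxylic acid or methoxy on that phenyl would track compound 3 or compound 4.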